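One Hydroxyl Shift, Tried Twice, Against Topoisomerase 1

This account rests on a few compounds, and the source may have more. Where it says the series, first, only, none or still open, it means among the compounds named here.

Three compounds have been measured in an assay on isolated protein for inhibition of DNA topoisomerase 1 (Homo sapiens), with a stated time of 30 min, tested at 100 uM; on this read-out higher numbers stand for a stronger effect at the one concentration tested and lower numbers for a weaker effect:

Compound 1 `Oc1cccc(-c2cc(-c3cccs3)cc(-c3ccccc3O)n2)c1` gives 83.2%.
Compound 2 `Oc1ccc(-c2cc(-c3cccs3)cc(-c3ccccc3O)n2)cc1` gives 72.2%.
Compound 3 `Oc1cccc(-c2cc(-c3ccoc3)cc(-c3cccc(O)c3)n2)c1` gives 44.2%.

Compound 1 and compound 2 share a core and differ by 4-hydroxyphenyl in place of 3-hydroxyphenyl on an aromatic carbon. This change gave a number 11 percentage points lower from compound 1 to compound 2 (beyond the scatter). Compound 3 stands lowest of the three, and its gaps to compound 2 and to compound 1 both lie beyond the usual scatter. How the core of compound 3 differs from the core of compound 1 is not broken down here.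

Compound 4 `Oc1ccc(-c2cc(-c3ccoc3)cc(-c3cccc(O)c3)n2)cc1` has not yet been measured. It differs from compound 3 by 4-hydroxyphenyl in place of 3-hydroxyphenyl on an aromatic carbon. Going by the values given here, this is the same kind of change as the one from compound 1 to compound 2, but not the same: in compound 1 the place is meta to a 2-hydroxyphenyl group and meta to a thiophen-2-yl group, while in compound 3 it is meta to a 3-hydroxyphenyl group and meta to a furan-3-yl group. Among the compounds with values here, the surroundings of the change therefore differ, and only one earlier example of the change exists.

Within the data shown here, for compound 4 the expected step is a number 11.2 percentage points lower from compound 3 to compound 4 (beyond the scatter) in this assay, resting on the one earlier step of a number 11 percentage points lower from compound 1 to compound 2 (beyond the scatter). Compound 4 is estimated at 33%, most likely between 15% and 52%.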

Compound 4, a percentage reported as inhibition, at one concentration (the size of the read-out at that concentration, not a potency): 37.4%
Compound 4: the middle estimate sits 4.4 percentage points below what was measured; the measured number falls inside the stated range.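

In this assay, 4-hydroxyphenyl in place of 3-hydroxyphenyl gave a number 6.8 percentage points lower from compound 3 to compound 4 (within the scatter) on the second core, so on this core the step cannot be told apart from ordinary variation between repeats. Set beside the first example, the size of the step carried over from one core to the other as far as this read-out can tell: the same change on two cores in this assay, a number 11 percentage points lower (beyond the scatter) from compound 1 to compound 2 and a number 6.8 percentage points lower (within the scatter) from compound 3 to compound 4, 4.2 percentage points apart, within the scatter of two such steps. Going by these compounds alone, this is encouraging for treating the change as roughly transferable between these two cores, but it rests on only two pairs, shows no firm drop on the second core, and cannot say which of the several differences between the cores might matter, or whether a real difference smaller than the scatter is hidden here.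

The compounds shown leave open whether the step would hold on a third core, for example one carrying a different group where furan-3-yl sits, and whether the stronger and weaker effects seen at this one concentration would look the same at other concentrations. They also leave open what would happen if the hydroxyl on the moved ring gave way to an amine, a carboxylic acid or a methoxy group, or if that ring were plain phenyl.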